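Propargyl to propyl at the sulfur: expected effect

A few compounds are considered here, and "the series" means these few. Any claim that something is new, unique, unknown or untested is made for them only; others in the source may bear on it.

Compound 3 `C#CCSc1nc(N/N=C/c2cc(OC)c(OC)c(OC)c2)c2nnn(Cc3ccccc3)c2n1` gives 17000 nM in a functional assay on MCF7 cells (Homo sapiens) for antiproliferative activity, read by MTT assay, with a stated time of 72 h (a higher number here means a weaker inhibitor, a lower number a stronger inhibitor), the lowest of the two numbers shown. Compound 1 `CCCSc1nc(N/N=C(\C)c2ccccc2O)c2nnn(Cc3ccc(Cl)cc3)c2n1` gives 42600 nM in this assay, a step beyond the scatter from compound 3. Compound 2 `CCCSc1nc(N/N=C/c2ccc(Cl)cc2)c2nnn(Cc3ccccc3)c2n1` reaches only > 64000 nM in this assay, which is a limit and not a number (the limit of > 64000 nM in this assay, at which 1 of the 3 values shown sits). Going by the values given here, no two measured compounds differ in one place, so no measured step carries over to the next change. Compound 4 `CCCSc1nc(N/N=C/c2cc(OC)c(OC)c(OC)c2)c2nnn(Cc3ccccc3)c2n1` differs from compound 3 by ethyl in place of ethynyl on a saturated chain carbon bound to a sulfur, propargyl to propyl on the sulfur. Nothing measured speaks to this change; the expected step is small, none beyond the scatter, estimated as a 1.3-fold higher number from compound 3 to compound 4 (0.11 log units; within the scatter). Compound 4 is therefore expected at 22000 nM, within 8000 nM to 60000 nM.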

Compound 4, half-maximal inhibitory concentration: > 64000 nM
Compound 4: no number, only a limit; the forecaster's own chance of this, stated with the estimate: 20%; middle value at least 2.9-fold (0.46 log units) away from the limit.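

Going by these compounds alone, this is the first pair that differs in one place, and it shows that the group on the sulfur matters: propargyl to propyl gives an at least 3.7-fold higher number from compound 3 to compound 4 (0.57 log units; beyond the scatter) in this assay. The saturated propyl chain does not keep the activity that compound 3 has with propargyl. Compound 4 stands at a limit of the assay and not at a number, so the step has only a lower bound: the limit of > 64000 nM in this assay, at which 2 of the 4 values shown sit.

The compounds shown leave open whether a nitrile in place of ethynyl, or a longer chain ending in a triple bond, would keep the activity of compound 3. From the compounds shown here alone, whether this step carries over to other groups on the shared core also stays open.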